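The compounds below may be only part of what the source reports. "The series", "measured", "known", "first", "only" and "open" are said of these compounds alone.

Among the compounds with values here, compound 2 `CCCCCCCCN1C(=O)[C@H](Cc2ccc(-c3cccc(CN(CCCC)C(=O)OC)c3)cc2)N(C)C(=O)[C@@H]1C` gives 2.7 nM in a functional assay for agonist activity at follicle-stimulating hormone receptor (Homo sapiens), read by a luciferase reporter (on this read-out lower numbers stand for an effect already at smaller amounts and higher numbers for an effect only at larger amounts of compound), the lower of the two numbers known so far; compound 1 `CCCCCCN1C(=O)[C@H](Cc2ccc(-c3cccc(CN(CCCC)C(=O)OC)c3)cc2)N(C)C(=O)[C@@H]1C` gives 8.9 nM in this assay, and the step of a 3.3-fold lower number from compound 1 to compound 2 (0.52 log units; beyond the scatter) lies beyond the scatter. Compound 3 `CCCCCCCCN1C(=O)[C@H](Cc2ccc(-c3cccc(CN(COC)C(C)=O)c3)cc2)N(C)C(=O)[C@@H]1C` differs from compound 2 by acetyl(methoxymethyl)amino in place of butyl(methoxycarbonyl)amino on a saturated chain carbon bound to an aromatic carbon. Within the data shown here, no measured step touches this part of the molecule; the only step known concerns the chain on the ring nitrogen. Among the measured compounds shown here, the expectation for compound 3 in this assay therefore rests on no direct precedent, and a moderate loss is estimated as a 3.0-fold higher number from compound 2 to compound 3 (0.47 log units; beyond the scatter), giving an expected value of 8 nM with a range from 2 nM to 40 nM.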

Compound 3, half-maximal effective concentration: 9.7 nM
Beside the measured number, compound 3's estimate is 1.2-fold (0.08 log units) below it; low and high end bracket the measured number.
By their numbers in this assay, from the lowest: compound 2; then compounds 1 and 3 (each within the scatter of the next).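

In this assay, the change to acetyl(methoxymethyl)amino on a saturated chain carbon bound to an aromatic carbon gives a 3.6-fold higher number from compound 2 to compound 3 (0.56 log units; beyond the scatter), the first sign that this position affects the number, though compound 3 still reads 9.7 nM. Both substituents on the nitrogen change in this one step, so the shift cannot be assigned to either alone. No evidence on hand accounts for the shift. On these data alone, it remains open how a free secondary amine or a carboxylic acid would read at this place, and whether acetyl paired with butyl alone would match compound 2.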